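A few compounds are considered here, and "the series" means these few. Any claim that something is new, unique, unknown or untested is made for them only; others in the source may bear on it.

Three compounds sharing one core, and differing only in the group on an amine nitrogen, have been measured in a functional assay on HeLa cells (Homo sapiens) for inhibition, read by sulforhodamine B assay; on this read-out lower numbers stand for stronger inhibition and higher numbers for weaker inhibition. Compound 1 `Cc1ccc(NC2=CC(=O)c3c(nc4n3[C@H]3OC[C@@H](O)[C@H]3OC4)C2=O)cc1` gives 6590 nM, compound 2 `COc1ccccc1NC1=CC(=O)c2c(nc3n2[C@H]2OC[C@@H](O)[C@H]2OC3)C1=O` gives 7460 nM, and compound 3 `O=C1C(NCc2ccccc2)=CC(=O)c2c1nc1n2[C@H]2OC[C@@H](O)[C@H]2OC1` gives 11000 nM. Compound 3 therefore stands within the scatter of both others, with a 1.5-fold higher number from compound 2 to compound 3 (0.17 log units; within the scatter) and a 1.7-fold higher number from compound 1 to compound 3 (0.22 log units; within the scatter). Compound 4 `CCOc1ccccc1NC1=CC(=O)c2c(nc3n2[C@H]2OC[C@@H](O)[C@H]2OC3)C1=O` keeps the core and carries 2-ethoxyphenyl in place of benzyl on an amine nitrogen. The closest guide is compound 2 at 7460 nM, which has 2-methoxyphenyl on that nitrogen. The step of a 1.5-fold higher number from compound 2 to compound 3 (0.17 log units; within the scatter) is the one that bears most directly on the change, and a 1.1-fold higher number from compound 1 to compound 2 (0.05 log units; within the scatter) shows a further exchange of groups on the same nitrogen. Among the compounds with values here, all three measured steps lie within the scatter, although the set is small and no measured compound carries 2-ethoxyphenyl itself. No step beyond the scatter is therefore expected in this assay, and the estimated step is a 1.4-fold lower number from compound 3 to compound 4 (0.15 log units; within the scatter). The estimated value for compound 4 is 7800 nM, with an expected range from 4000 nM to 14000 nM.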

Compound 4, half-maximal inhibitory concentration: 8300 nM
Estimate against measurement, compound 4: 1.1-fold (0.03 log units) below, within the range that was stated.
By their numbers in this assay, from the lowest: compounds 1, 2, 4 and 3 (each within the scatter of the next).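

In this assay, within the data shown here, methyl in place of hydrogen on a saturated chain carbon bound to an oxygen on an aromatic ring, the exchange that separates 2-methoxyphenyl from 2-ethoxyphenyl, gives a step within the scatter (a 1.1-fold higher number from compound 2 to compound 4 (0.05 log units; within the scatter)), so this position now has a comparison of two closely related alkoxy groups on the phenyl ring, which the earlier compounds did not offer. The steps from the other two groups on the amine nitrogen also stay within the scatter, both from benzyl (a 1.3-fold lower number from compound 3 to compound 4 (0.12 log units; within the scatter)) and from 4-methylphenyl (a 1.3-fold higher number from compound 1 to compound 4 (0.10 log units; within the scatter)), so all four groups shown at this nitrogen now lie within the scatter of one another, although 2-ethoxyphenyl brings an added oxygen and more heavy atoms than benzyl. Nothing available explains why these exchanges leave the read-out within the scatter.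

The compounds shown leave open whether a group of another kind on this nitrogen, such as a cyclohexyl ring, a pyridine ring or a phenyl ring bearing a carboxylic acid, would give a step beyond the scatter. They also leave open what a change elsewhere on the shared core, such as at its hydroxyl group, would do.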